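This account rests on a few compounds, and the source may have more. Where it says the series, first, only, none or still open, it means among the compounds named here.

Of the compounds shown here, three sharing one core have been tested in a functional assay on A498 cells (Homo sapiens) for cytotoxicity (a lower number here means a stronger inhibitor of growth, a higher number a weaker inhibitor of growth), and they differ only in the group on a double-bonded ring carbon. Compound 1 `CSc1ccc(C2=C(c3ccc(F)c(C)c3)C(=O)N3CCCC3C2)cc1`, with 4-fluoro-3-methylphenyl there, gives 300 nM. Compound 2 `CSc1ccc(C2=C(c3ccc(Br)cc3)C(=O)N3CCCC3C2)cc1`, with 4-bromophenyl, gives 7000 nM. Compound 3 `CSc1ccc(C2=C(c3ccc(C)cc3)C(=O)N3CCCC3C2)cc1`, with 4-methylphenyl, gives 4000 nM.

Compound 3 therefore cannot be separated from compound 2, and both lie well above compound 1. The measured steps show this: a 1.8-fold lower number from compound 2 to compound 3 (0.24 log units; within the scatter), whereas a 13-fold higher number from compound 1 to compound 3 (1.12 log units; beyond the scatter) and a 23-fold higher number from compound 1 to compound 2 (1.37 log units; beyond the scatter).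

The next compound, compound 4 `CSc1ccc(C2=C(c3ccc(SC)cc3)C(=O)N3CCCC3C2)cc1`, keeps the core and changes one group: methylsulfanyl in place of methyl on an aromatic carbon. In words, this places methylsulfanyl in place of methyl on an aromatic carbon, para to a large group.

The closest guide is the other exchange at this same spot, a 1.8-fold lower number from compound 2 to compound 3 (0.24 log units; within the scatter), which stayed within the scatter. The two large steps involve the 4-fluoro-3-methylphenyl group, which plays no part in this change. No step beyond the scatter is therefore expected in this assay, although this rests on a single comparison. The expected step is a 1.1-fold higher number from compound 3 to compound 4 (0.05 log units; within the scatter). For compound 4 the estimated value is 4500 nM, with an expected range of 1500 nM to 13000 nM.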

Compound 4, concentration for 50% growth inhibition: 15000 nM
Compound 4: the middle estimate sits 3.3-fold (0.52 log units) below what was measured, outside the stated range (above it).
By their numbers in this assay, from the lowest: compound 1; then compounds 3 and 2 (each within the scatter of the next); then compound 4.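

In this assay, the group at this spot, para to a large group, can shift the result after all, even though bromo and methyl could not be told apart: methylsulfanyl in place of methyl gives a 3.8-fold higher number from compound 3 to compound 4 (0.57 log units; beyond the scatter) and methylsulfanyl in place of bromo gives a 2.1-fold higher number from compound 2 to compound 4 (0.33 log units; beyond the scatter) in the same direction, towards weaker growth inhibition. Both steps are modest, and they remain much smaller than a 50-fold higher number from compound 1 to compound 4 (1.70 log units; beyond the scatter) when the whole 4-fluoro-3-methylphenyl group is exchanged for 4-(methylsulfanyl)phenyl, so the 4-fluoro-3-methylphenyl group of compound 1 still stands apart from the other three groups. Nothing available here explains why methylsulfanyl differs from methyl or bromo at this spot.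

On these data alone, what an amine, a carboxylic acid or a longer chain such as ethylsulfanyl would give at this same spot remains open. The compounds shown also cannot say whether the large gap to compound 1 belongs to its fluoro group, to its extra methyl group, or to the two together.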